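This account rests on a few compounds, and the source may have more. Where it says the series, first, only, none or still open, it means among the compounds named here.

Measured in a functional assay on DU-145 cells (Homo sapiens) for inhibition, read by MTT assay, with a stated time of 48 h; a higher number here means a weaker inhibitor, a lower number a stronger inhibitor:

Compound 1 `CS(=O)(=O)Nc1ccc(-n2cc(-c3ccccc3)nn2)cc1Oc1ccccc1` gives 14200 nM.
Compound 2 `CS(=O)(=O)Nc1ccc(-n2cc(OCc3ccccc3)nn2)cc1Oc1ccccc1` gives 10700 nM.
Compound 3 `Cc1ccc(-c2cn(-c3ccc(NS(C)(=O)=O)c(Oc4ccccc4)c3)nn2)cc1` gives 11200 nM.

Compound 2 has the lowest of the three numbers in this assay, but its nearest neighbour is compound 3 at a 1.0-fold higher number from compound 2 to compound 3 (0.02 log units; within the scatter) and its furthest is compound 1 at a 1.3-fold lower number from compound 1 to compound 2 (0.12 log units; within the scatter), so the three compounds cannot be told apart on these data.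

The next compound is compound 4 `CS(=O)(=O)Nc1ccc(-n2cc(COc3ccc(Cl)cc3)nn2)cc1Oc1ccccc1`. It differs from compound 2 by (4-chlorophenoxy)methyl in place of benzyloxy on an aromatic carbon.

Within the data shown here, the steps that bear on this change are those at the same position of the shared core: a 1.3-fold lower number from compound 1 to compound 2 (0.12 log units; within the scatter), a 1.3-fold lower number from compound 1 to compound 3 (0.10 log units; within the scatter) and a 1.0-fold higher number from compound 2 to compound 3 (0.02 log units; within the scatter). Every one of them lies within the scatter, so across phenyl, benzyloxy and 4-methylphenyl at this carbon the number in this assay has not moved measurably. Among the measured compounds shown here, there is no measured step for a (4-chlorophenoxy)methyl group or for a chlorine, so nothing points to a shift in either direction; the expectation is of a step no larger than the scatter.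

Compound 4 is therefore expected at 10500 nM, with a range of 5000 nM to 22000 nM. The expected step from compound 2 is a 1.0-fold lower number from compound 2 to compound 4 (0.01 log units; within the scatter), estimated as no change beyond the scatter.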

Compound 4, half-maximal inhibitory concentration: 6400 nM
Compound 4: the middle estimate sits 1.6-fold (0.22 log units) above what was measured; the measured number falls inside the stated range.
By their numbers in this assay, from the lowest: compounds 4, 2, 3 and 1 (each within the scatter of the next, the first and the last beyond it).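

In this assay, among these compounds, the (4-chlorophenoxy)methyl group gives the first step at this carbon of the five-membered aromatic ring that lies beyond the scatter, a 2.2-fold lower number from compound 1 to compound 4 (0.35 log units; beyond the scatter), and that step is modest. The other two steps to compound 4 stay within the scatter, a 1.7-fold lower number from compound 2 to compound 4 (0.22 log units; within the scatter) and a 1.8-fold lower number from compound 3 to compound 4 (0.24 log units; within the scatter), so the separation holds against the phenyl group of compound 1 only, and compound 4 cannot be told apart from compound 2 or compound 3. The position thus accepts a chlorine-bearing aryl ether on a one-carbon link while the number stays within the range of the series, and that range is now just wide enough to be read at its two ends.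

No evidence on hand accounts for the step. From the compounds shown here alone, it remains open whether the chlorine or the swapped order of oxygen and methylene in the link carries the step, which the plain phenoxymethyl group would address, and how an amine, a carboxylic acid or a longer chain at this carbon would read in this assay.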